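An Aryl Swap on the Amide Carbonyl

The source may report more compounds than this note shows. Statements on the series, on what has been measured and on what is new or still open speak of the compounds shown alone.

Compound 1 `COc1ccc(Cl)cc1C(=O)NCC1CCN(S(=O)(=O)NC(=O)NC2CCCCC2)CC1` and compound 2 `Cc1cccc(C(=O)NCCC2CCN(S(=O)(=O)NC(=O)NC[C@@H]3C[C@@H]4C=C[C@@H]3C4)CC2)n1` have both been tested in a functional assay on the whole organism (blood) with Rattus norvegicus as the target, with stated times of 24 h and 1 h, at a dose of 5 mg/kg by the intraperitoneal route; a higher number here means a stronger effect of the compound at the dose given, a lower number a weaker effect. Compound 1 gives 20%, and compound 2 gives 20%, so compound 2 stands level with compound 1 within the scatter. Compound 3 `O=C(NC[C@@H]1C[C@@H]2C=C[C@@H]1C2)NS(=O)(=O)N1CCC(CCNC(=O)c2cccc3c2OCCO3)CC1` has not yet been measured in this assay. It differs from compound 2 in one place: 2,3-dihydro-1,4-benzodioxin-5-yl in place of 6-methylpyridin-2-yl on a carbonyl carbon. Among the measured compounds shown here, no step between measured compounds shows what such a change does here, so no step beyond the scatter is expected in either direction. Compound 3 is therefore expected to give about 20% in this assay, from 5% to 40%, an expected step of no change at the digits printed from compound 2 to compound 3 (within the scatter).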

Compound 3, a percentage reported as activity, at one dose (the size of the read-out at that dose, not a potency): 11%
Estimate against measurement, compound 3: 9 percentage points above; the measured number falls inside the stated range.
By their numbers in this assay, from the lowest: compounds 3, 1 and 2 (each within the scatter of the next).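

In this assay, the group on the amide carbonyl now has its first measured step: 2,3-dihydro-1,4-benzodioxin-5-yl in place of 6-methylpyridin-2-yl gives a number 9 percentage points lower from compound 2 to compound 3 (within the scatter). At this dose, then, exchanging a six-membered aromatic ring with one hetero atom for the two-ring group produces no step beyond the scatter. Nothing measured here bears on the reason for this result. From the compounds shown here alone, whether a phenyl, a carboxylic acid or an amine on this carbonyl would move the read-out beyond the scatter remains open.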